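Removing the methyl from compound 1: working notes

The source may report more compounds than this note shows. Statements on the series, on what has been measured and on what is new or still open speak of the compounds shown alone.

Measured in a functional assay on HT-29 cells (Homo sapiens) for cytotoxicity, read by MTT assay, with a stated time of 72 h; on this read-out lower numbers stand for stronger inhibition and higher numbers for weaker inhibition:
- compound 1 `COC(=O)c1sc2c(C)cccc2c1Nc1cc(OC)c(OC)c(OC)c1` gives 552 nM
- compound 2 `COC(=O)c1sc2nc(C)ccc2c1Nc1cc(OC)c(OC)c(OC)c1` gives 0.35 nM
- compound 3 `COC(=O)c1sc2ncccc2c1Nc1cc(OC)c(OC)c(OC)c1` gives 542 nM

Compound 1 and compound 3 share the high end of these numbers, within the scatter of each other, and compound 2 lies far lower. Compound 4 `COC(=O)c1sc2ccccc2c1Nc1cc(OC)c(OC)c(OC)c1` is still unmeasured. It differs from compound 1 as follows: hydrogen in place of methyl on an aromatic carbon. For the measured compounds named here, the one measured step of this kind is a 1500-fold higher number from compound 2 to compound 3 (3.19 log units; beyond the scatter), but it lies on another core, so it transfers poorly. Compound 1 already sits level with methyl-free compound 3 at 542 nM. In this assay no step beyond the scatter is therefore expected, though a rise remains possible. The expected step is a 1.3-fold higher number from compound 1 to compound 4 (0.10 log units; within the scatter). For compound 4 the estimated value is 700 nM, with an expected range from 120 nM to 4000 nM.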

Compound 4, half-maximal inhibitory concentration: 299 nM
Compound 4: the middle estimate sits 2.3-fold (0.37 log units) above what was measured; the measured number falls inside the stated range.
By their numbers in this assay, from the lowest: compound 2; then compounds 4, 3 and 1 (each within the scatter of the next).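

On the core of compound 1, in this assay, hydrogen in place of methyl on an aromatic carbon gives no step beyond the scatter (a 1.8-fold lower number from compound 1 to compound 4 (0.27 log units; within the scatter)). The methyl at this position is therefore not needed to hold the number on this core. The size of the same change depends on the core: the same change on two cores in this assay, a 1500-fold higher number (3.19 log units; beyond the scatter) from compound 2 to compound 3 and a 1.8-fold lower number (0.27 log units; within the scatter) from compound 1 to compound 4, 2900-fold (3.46 log units) apart, beyond the scatter of two such steps.

From the compounds shown here alone, whether an amine or a methoxy group at this position would move the number remains open. Also open, going by these compounds, is whether ethyl, a longer chain, on the core of compound 3 would keep the low number of compound 2 (0.35 nM).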